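The source may report more compounds than this note shows. Statements on the series, on what has been measured and on what is new or still open speak of the compounds shown alone.

Compound 1 `C[C@@H]1CN(c2ncccc2Cl)CCN1c1nc2cc(Cl)ccc2[nH]1`, compound 2 `Cc1cc2nc(N3CCN(c4ncccc4Cl)C[C@H]3C)n(C)c2cc1C` and compound 3 `CC(C)(C)c1ccc2oc(N3CCN(c4ncccc4Cl)CC3)nc2c1` were tested in a functional assay on HEK293 cells for antagonist activity at transient receptor potential cation channel subfamily V member 1 (Homo sapiens), read by FLIPR; a higher number here means a weaker inhibitor, a lower number a stronger inhibitor. Compound 1 gives 325 nM, compound 2 gives 3130 nM and compound 3 gives 2140 nM. Among these three numbers, compound 3 stands second highest: its gap to compound 2 lies within the scatter of repeated measurements, so the two cannot be told apart, while compound 1 sits beyond the scatter with the clearly lower number, making it the stronger inhibitor of the three.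

Compound 4 `C[C@@H]1CN(c2ncccc2Cl)CCN1c1nc2cc(C(C)(C)C)ccc2o1` has not yet been measured. It differs from compound 3 in one place: methyl in place of hydrogen on a saturated ring carbon. Going by the values given here, no pair of measured compounds differs by exactly this change, so there is no measured step to lean on; compounds 1 and 2 do carry such a methyl group, but on different cores, and their numbers tell nothing direct about this change. The step from compound 3 is therefore expected to be small, with a slight lean toward a lower number, and is estimated as a 1.8-fold lower number from compound 3 to compound 4 (0.25 log units; within the scatter). Compound 4 is accordingly expected to give about 1200 nM in this assay, with a likely range from 400 nM to 4000 nM.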

Compound 4, half-maximal inhibitory concentration: 305 nM
Compound 4: middle estimate off by 3.9-fold (0.59 log units), on the high side; the whole stated range lies above it.
By their numbers in this assay, from the lowest: compounds 4 and 1 (each within the scatter of the next); then compounds 3 and 2 (each within the scatter of the next).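

In this assay, methyl in place of hydrogen on a saturated ring carbon, next to the ring nitrogen, gives a 7.0-fold lower number from compound 3 to compound 4 (0.85 log units; beyond the scatter). Going by these compounds alone, this is the first measured pair that isolates this change, and it shows that the position is sensitive: one added carbon, with no other difference between the two structures, moves the number well past the usual variation between repeat measurements. Nothing available here explains how the methyl produces this step.

Still open, on these data alone, is whether hydrogen and methyl are just two points on a longer trend, since an ethyl group or a hydroxymethyl group at this ring carbon could lower the number further or raise it again. As far as these compounds go, it is also open whether the same methyl step would hold on the cores of compound 1 and compound 2.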